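Moving the halogen on the phenoxy tail

The source may hold more compounds than are shown below. What is called first, only, known or untested is meant among the compounds shown, and "the series" means these compounds.

Compound 1, `NC1=NC2(CCOCC2)N(OCCCOc2ccc(F)cc2)C(N)=N1`: > 90%
Compound 2, `NC1=NC2(CCSCC2)N(OCCCOc2ccc(Cl)cc2)C(N)=N1`: > 90%
Compound 3, `NC1=NC2(CCSCC2)N(OCCCOc2ccc(Br)cc2)C(N)=N1`: > 90%

In an assay on isolated protein for inhibition of Dihydrofolate reductase (Homo sapiens), read by spectrophotometry, using NADPH, with stated times of 5 s and 6 min, tested at 5 uM (a lower number here means a weaker effect, a higher number a stronger effect of the compound at the concentration tested), compound 1 gives > 90%, which is a limit of the assay. Compound 2 gives > 90%, also a limit. Compound 3 gives > 90%, again a limit. The step that the two limits leave unreadable from compound 2 to compound 3 cannot be sized because of the limit of > 90% in this assay, at which 3 of the 3 values shown sit.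

Compound 4, `NC1=NC2(CCOCC2)N(OCCCOc2ccccc2Br)C(N)=N1`, differs from compound 1 by 2-bromophenyl in place of 4-fluorophenyl on an oxygen on a saturated carbon. Within the data shown here, no measured step bears directly on this change, and the one halogen swap that was measured, bromo in place of chloro on an aromatic carbon, is itself unreadable. Compound 4 is therefore expected to remain at the same limit, with the step that the limit leaves unreadable from compound 1 to compound 4 estimated as none beyond the scatter. The estimate for compound 4 is 92%, expected between 80% and 99%.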

Compound 4, a percentage reported as inhibition, at one concentration (the size of the read-out at that concentration, not a potency): 83.8%
Compound 4: middle estimate off by 8.2 percentage points, on the high side; measured number inside the range.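

Among these compounds, compound 4 gives the first reading in this assay that is a number and not a limit, so 2-bromophenyl in place of 4-fluorophenyl on an oxygen on a saturated carbon can now be read in one direction, as a number at least 6.2 percentage points lower from compound 1 to compound 4 (that floor lies within the scatter). Going by these compounds, the full size of this step stays unknown, because compound 1 sits at a limit: the limit of > 90% in this assay, at which 3 of the 4 values shown sit.

On these data alone, whether the halogen itself or its place on the ring carries the step stays open, as both change together in compound 4. Also open, as far as these compounds go, is how an amine or a carboxylic acid would read on the same phenyl ring.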